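The compounds below may be only part of what the source reports. "The series", "measured", "known", "first", "only" and "open" are said of these compounds alone.

Measured so far in a functional assay on RAW264.7 cells (Mus musculus) for inhibition, read by Griess assay, with stated times of 1 h and 24 h; on this read-out lower numbers stand for stronger inhibition and higher numbers for weaker inhibition:
Compound 1 `CCOCCOc1ccc(C(O)C2OC(=O)c3c(OC)cc(OC)cc32)cc1`: > 10000 nM
Compound 2 `COc1cc(OC)c2c(c1)C(C(O)c1ccc(OCc3ccc(Br)cc3)cc1)OC2=O`: 6530 nM

Compound 1 shows the entry > 10000 nM, which is a limit of the assay and not a number. Within the data shown here, that leaves compound 2, at 6530 nM, as the only true number available, so there is little to compare it with.

The next compound, compound 3 `COc1cc(OC)c2c(c1)C(C(O)c1ccc(OCc3ccc(OC(F)F)cc3)cc1)OC2=O`, keeps everything in compound 2 except one group, with difluoromethoxy in place of bromo on an aromatic carbon. This exchange has not yet been tested on any other pair of compounds.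

Among the measured compounds shown here, the only measured step is an at least 1.5-fold lower number from compound 1 to compound 2 (0.18 log units; that floor lies within the scatter). It came from 4-bromophenyl in place of ethoxymethyl, which is a different exchange, so it offers only weak guidance. With nothing pointing either way, no step beyond the scatter is expected in this assay. The estimated step is a 1.1-fold lower number from compound 2 to compound 3 (0.04 log units; within the scatter). For compound 3 the expected value is 6000 nM, with an estimated range from 2500 nM to 14000 nM.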

Compound 3, half-maximal inhibitory concentration: 5030 nM
Compound 3: middle estimate off by 1.2-fold (0.08 log units), on the high side; the measured number falls inside the stated range.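

In this assay, placing difluoromethoxy instead of bromo on this aromatic carbon, para to a large group, gives a 1.3-fold lower number from compound 2 to compound 3 (0.11 log units; within the scatter). Among these compounds, this is the first step here between two compounds with true numbers, and it shows that a group of 4 heavy atoms with one hydrogen-bond acceptor can replace a single bromine atom at this position without a change that can be told apart from ordinary repeat variation. The other new step, an at least 1.9-fold lower number from compound 1 to compound 3 (0.29 log units; that floor lies within the scatter), gives only a floor, and the full size of the gap cannot be read: the limit of > 10000 nM in this assay, at which 1 of the 3 values shown sits.

Bromo and difluoromethoxy therefore say little about how much this position can influence the read-out, and whether any substituent here can produce a step beyond the scatter remains open. As far as these compounds go, an amine, a carboxylic acid or a nitrile at this position would test that question with groups quite unlike these two, while the shared core and the hydroxyl-bearing link stay unexplored by these comparisons.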